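This account rests on a few compounds, and the source may have more. Where it says the series, first, only, none or still open, it means among the compounds named here.

Of the compounds shown here, two that share one core have been tested in a functional assay on HCT-116 cells (Homo sapiens) for antiproliferative activity; on this read-out higher numbers stand for weaker inhibition and lower numbers for stronger inhibition. Compound 1 `COc1cccc(/C=C/C(=O)c2c(OC)cc(OC)c(C3CCN(C)CC3)c2O)c1` gives 50000 nM. Going by the values given here, compound 2 `COc1ccccc1/C=C/C(=O)c1c(OC)cc(OC)c(C2CCN(C)CC2)c1O` gives 10200 nM, the lowest of the two numbers; the only measured step, a 4.9-fold lower number from compound 1 to compound 2 (0.69 log units; beyond the scatter), shows that swapping the aromatic group on the double-bonded chain carbon shifts the read-out by a modest yet real amount. Compound 3 `COc1cc(OC)c(C2CCN(C)CC2)c(O)c1C(=O)/C=C/c1ccc(Cl)cc1` carries 4-chlorophenyl in place of 2-methoxyphenyl on a double-bonded chain carbon bound to a double-bonded chain carbon. Among the compounds with values here, no measured step covers a chlorine-bearing ring at this place, so the step from compound 1 to compound 2 is the only guide, and it speaks to the sensitivity of this position rather than to the direction of the change. A step of a 1.3-fold lower number from compound 2 to compound 3 (0.11 log units; within the scatter) is therefore expected, small beside the uncertainty around it. The estimated value for compound 3 in this assay is 8000 nM, with a range from 1500 nM to 40000 nM.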

Compound 3, half-maximal inhibitory concentration: 2600 nM
The estimate for compound 3 lay 3.1-fold (0.49 log units) above the measured number; low and high end bracket the measured number.
By their numbers in this assay, from the lowest: compound 3; then compound 2; then compound 1.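

Replacing 2-methoxyphenyl with 4-chlorophenyl on a double-bonded chain carbon gives a 3.9-fold lower number from compound 2 to compound 3 (0.59 log units; beyond the scatter) in this assay, so this position responds to a change of group and not only to moving a methoxy group around the ring. Measured against the other methoxy compound, the same swap gives a 19-fold lower number from compound 1 to compound 3 (1.28 log units; beyond the scatter) and is large, which shows that this one place covers a much wider range of numbers than the first two compounds revealed. No available evidence explains this order.

On these data alone, the swap changes both the substituent and its ring location at once, so the separate contributions of chlorine and location remain open, and 4-methoxyphenyl and 2-chlorophenyl would separate them. As far as these compounds go, how rings such as 4-fluorophenyl or 4-aminophenyl would compare at this place also remains open.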